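Chain Length and Halide Swap in a Sulfonamide Series

The source may report more compounds than this note shows. Statements on the series, on what has been measured and on what is new or still open speak of the compounds shown alone.

Three analogues sharing one core have been measured in a functional assay on A-375 cells (Homo sapiens) for cytotoxicity, read by MTT assay; a lower number here means a stronger inhibitor, a higher number a weaker inhibitor. Compound 3 `O=S(=O)(NCCNc1nccc(-c2c(-c3cccc(F)c3)nc3sccn23)n1)c1ccc(F)cc1` gives 9450 nM and stands second highest of the three numbers; its nearest neighbour is compound 1 `O=S(=O)(NCCCNc1nccc(-c2c(-c3cccc(F)c3)nc3sccn23)n1)c1ccc(Br)cc1`, which gives 7040 nM, and the furthest is compound 2 `O=C(NCCCNc1nccc(-c2c(-c3cccc(F)c3)nc3sccn23)n1)c1ccc(F)cc1`, which gives 14900 nM. The step of a 1.3-fold higher number from compound 1 to compound 3 (0.13 log units; within the scatter) is within the scatter, while the step of a 2.1-fold higher number from compound 1 to compound 2 (0.33 log units; beyond the scatter) is a modest one beyond it; the step of a 1.6-fold lower number from compound 2 to compound 3 (0.20 log units; within the scatter) is again within the scatter.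

Compound 4 `O=S(=O)(NCCCNc1nccc(-c2c(-c3cccc(F)c3)nc3sccn23)n1)c1ccc(Cl)cc1` differs from compound 3 as follows: (((4-chlorophenyl)sulfonyl)amino)methyl in place of ((4-fluorophenyl)sulfonyl)amino on a saturated chain carbon, two bonds along the chain from a nitrogen on an aromatic ring. The change touches two things at once, the length of the chain and the halogen on the aromatic ring, and compound 4 therefore ends up most like compound 1, from which it differs only in the halogen. Within the data shown here, the only measured step on the chain length, a 1.3-fold higher number from compound 1 to compound 3 (0.13 log units; within the scatter), lies within the scatter, and no measured step bears on the halogen swap. The sulfonyl group is retained, so the modest step of a 2.1-fold higher number from compound 1 to compound 2 (0.33 log units; beyond the scatter) is not expected to apply.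

On this basis the author expects no step beyond the scatter from compound 3 to compound 4, a 1.3-fold lower number from compound 3 to compound 4 (0.10 log units; within the scatter), and estimates compound 4 at 7500 nM in this assay, within a range of 3500 nM to 16000 nM.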

Compound 4, half-maximal inhibitory concentration: 5900 nM
Estimate against measurement, compound 4: 1.3-fold (0.10 log units) above; the range from low to high includes it.
By their numbers in this assay, from the lowest: compounds 4, 1, 3 and 2 (each within the scatter of the next, the first and the last beyond it).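

In this assay, among these compounds, the step of a 1.2-fold lower number from compound 1 to compound 4 (0.08 log units; within the scatter) reads the halogen on its own for the first time, and this swap of chloro in place of bromo on an aromatic carbon stays within the scatter. The step of a 1.6-fold lower number from compound 3 to compound 4 (0.20 log units; within the scatter) shows that (((4-chlorophenyl)sulfonyl)amino)methyl in place of ((4-fluorophenyl)sulfonyl)amino on the saturated chain carbon also stays within the scatter, as the bromo pair, compound 1 and compound 3, had already done. The step of a 2.5-fold lower number from compound 2 to compound 4 (0.40 log units; beyond the scatter), with (4-chlorophenyl)sulfonyl in place of (4-fluorophenyl)carbonyl on an amine nitrogen, is modest but beyond the scatter, so a second sulfonyl compound now stands apart from compound 2 at the same chain, although the halogen differs as well as the linking group in both pairs.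

Nothing given here accounts for these steps. Chain length is still not separated from the halogen in any step shown, and it remains open how an unsubstituted phenyl, a methoxy group on that aromatic carbon or a longer chain would read.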